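A few compounds are considered here, and "the series" means these few. Any claim that something is new, unique, unknown or untested is made for them only; others in the source may bear on it.

Three compounds built on one shared core were run through an ADME assay on Vero cells (Chlorocebus sabaeus) for antiproliferative activity, read by MTT assay, with a stated time of 72 h; a lower number here means a stronger inhibitor, a higher number a weaker inhibitor. Compound 1, `CN(c1ccccc1Cl)S(=O)(=O)C1CC2OC1C(c1ccc(NC(=O)CCCCCCC(=O)O)cc1)=C2c1ccc(O)cc1`, gives > 100000 nM in this assay, a limit of the assay rather than a number. Compound 2, `CN(c1ccc(Cl)cc1)S(=O)(=O)C1CC2OC1C(c1ccc(NC(=O)CCCCCCC(=O)O)cc1)=C2c1ccc(O)cc1`, gives the limit > 100000 nM in this assay. Compound 3, `CCN(c1ccccc1Cl)S(=O)(=O)C1CC2OC1C(c1ccc(NC(=O)CCCCCCC(=O)O)cc1)=C2c1ccc(O)cc1`, gives the limit > 100000 nM in this assay. Compound 2 differs from compound 1 by 4-chlorophenyl in place of 2-chlorophenyl on a sulfonamide nitrogen, and the step that the two limits leave unreadable from compound 1 to compound 2 cannot be sized because of the limit of > 100000 nM in this assay, at which 3 of the 3 values shown sit. Compound 4, `CCN(c1ccc(Cl)cc1)S(=O)(=O)C1CC2OC1C(c1ccc(NC(=O)CCCCCCC(=O)O)cc1)=C2c1ccc(O)cc1`, has not yet been measured; it differs from compound 3 by 4-chlorophenyl in place of 2-chlorophenyl on a sulfonamide nitrogen, the same change carried out on a core that differs by methyl in place of hydrogen on a saturated chain carbon bound to a sulfonamide nitrogen. With the earlier step that the two limits leave unreadable from compound 1 to compound 2 unreadable, the step is expected to be a number no higher from compound 3 to compound 4 (the limit leaves the size open). Compound 4 is expected to give 100000 nM in this assay, resting on the limits seen so far.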

Compound 4, half-maximal inhibitory concentration: > 100000 nM
Compound 4: a limit, no number; the forecaster's own chance of this, stated with the estimate: 90%; the middle value lies on the limit itself.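

Within the data shown here, no step from compound 1, compound 2 or compound 3 to compound 4 can be read, because each value is a limit of the assay and not a number: the limit of > 100000 nM in this assay, at which 4 of the 4 values shown sit. Whether 4-chlorophenyl in place of 2-chlorophenyl, or ethyl in place of methyl, changes the true potency of these compounds in this assay stays open.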